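Amide Variation Across Two Cores

A few compounds are considered here, and "the series" means these few. Any claim that something is new, unique, unknown or untested is made for them only; others in the source may bear on it.

Compound 1 `O=C(NC1CCCCC1)c1cc(Oc2ccc(/C=C/c3ccccn3)cc2)ccn1` carries a cyclohexylamino group on the carbonyl carbon. In a functional assay on A549 cells (Homo sapiens) for antiproliferative activity, read by CCK-8 assay, with a stated time of 48 h (a lower number here means a stronger inhibitor, a higher number a weaker inhibitor), compound 1 gives 12500 nM. Compound 2 `O=C(c1cc(Oc2ccc(/C=C/c3ccccn3)cc2)ccn1)N1CCCC1` differs from it by pyrrolidin-1-yl in place of cyclohexylamino on a carbonyl carbon. In this assay compound 2 gives 15600 nM. That change gave a 1.2-fold higher number from compound 1 to compound 2 (0.10 log units; within the scatter). Compound 3 `O=C(NC1CCCCC1)c1cc(Oc2ccc(/C=C/c3ccncc3)cc2)ccn1` has a different core; the difference is pyridin-4-yl in place of pyridin-2-yl on a double-bonded chain carbon bound to a double-bonded chain carbon. In this assay compound 3 gives 16800 nM, and the step is a 1.3-fold higher number from compound 1 to compound 3 (0.13 log units; within the scatter). Compound 4 `O=C(c1cc(Oc2ccc(/C=C/c3ccncc3)cc2)ccn1)N1CCCC1` has not yet been measured. It differs from compound 3 by pyrrolidin-1-yl in place of cyclohexylamino on a carbonyl carbon, the same change as between compound 1 and compound 2, at a place described in the same words. Because that change gave a 1.2-fold higher number from compound 1 to compound 2 (0.10 log units; within the scatter), a similar small step is expected for compound 4, namely a 1.2-fold higher number from compound 3 to compound 4 (0.08 log units; within the scatter). Compound 4 is therefore estimated at 20000 nM, most likely between 10000 nM and 40000 nM.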

Compound 4, half-maximal inhibitory concentration: 18600 nM
Beside the measured number, compound 4's estimate is 1.1-fold (0.03 log units) above it; the range from low to high includes it.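

In this assay, pyrrolidin-1-yl in place of cyclohexylamino gives a 1.1-fold higher number from compound 3 to compound 4 (0.04 log units; within the scatter), and pyridin-4-yl in place of pyridin-2-yl gives a 1.2-fold higher number from compound 2 to compound 4 (0.08 log units; within the scatter). Going by these compounds alone, the amide change reads alike on both cores, but every step here lies within the scatter, so this shows only that neither step can be told from noise on either core, not that a change with a real effect would carry from one core to another: the same change on two cores in this assay, a 1.2-fold higher number (0.10 log units; within the scatter) from compound 1 to compound 2 and a 1.1-fold higher number (0.04 log units; within the scatter) from compound 3 to compound 4, 1.1-fold (0.05 log units) apart, within the scatter of two such steps. The pyridinyl change reads the same way on both amides: the same change on two cores in this assay, a 1.3-fold higher number (0.13 log units; within the scatter) from compound 1 to compound 3 and a 1.2-fold higher number (0.08 log units; within the scatter) from compound 2 to compound 4, 1.1-fold (0.05 log units) apart, within the scatter of two such steps. The compounds shown leave open whether a morpholine or a piperidine on the carbonyl carbon would give a larger step. Going by these compounds, whether a phenyl in place of the pyridinyl group would do so also remains open.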